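This account rests on a few compounds, and the source may have more. Where it says the series, first, only, none or still open, it means among the compounds named here.

Measured so far in a functional assay on HCT-116 cells (Homo sapiens), read by MTT assay, with a stated time of 72 h; a lower number here means a stronger inhibitor, a higher number a weaker inhibitor:
- compound 1 `Cc1nc(N)c2c(-c3cccs3)cn([C@@H]3O[C@H](CO)[C@@H](O)[C@H]3O)c2n1`: > 20000 nM
- compound 2 `Nc1nc2c(c(-c3ccco3)cn2[C@@H]2O[C@H](CO)[C@@H](O)[C@H]2O)c(=O)[nH]1`: > 20000 nM

Both entries are limits of the assay, not numbers.

On the numbers available, compound 2 stands at the limit of > 20000 nM in this assay, at which 2 of the 2 values shown sit. Within the data shown here, no measured step connects the two compounds, so the series offers no numerical size for any structural change.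

Compound 3 `Nc1nc2c(c(-c3ccoc3)cn2[C@@H]2O[C@H](CO)[C@@H](O)[C@H]2O)c(=O)[nH]1` is the next compound to be read in this assay. It keeps the core of compound 2 and carries furan-3-yl in place of furan-2-yl on an aromatic carbon. The two compounds have the same atoms, joined differently. The attachment point lies on a five-membered aromatic ring with 1 nitrogen, part of a fused or bridged system of two rings.

No step beyond the scatter is expected in either direction, and a further limit is the likeliest report. The expected change is a number no higher from compound 2 to compound 3 (the limit leaves the size open), as an estimate. For compound 3 the estimated value is 20000 nM, with an expected range from 8000 nM to 40000 nM.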

Compound 3, half-maximal inhibitory concentration: 14200 nM
For compound 3 the middle estimate is 1.4-fold (0.15 log units) above the measured one; the range from low to high includes it.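

In this assay, compound 3 gives 14200 nM, the only one of the three results shown that is a number and not a limit. Among these compounds, at this position, on an aromatic carbon of a five-membered aromatic ring with 1 nitrogen, placing furan-3-yl in place of furan-2-yl gives an at least 1.4-fold lower number from compound 2 to compound 3 (0.14 log units; that floor lies within the scatter), which is the first size attached to any structural change, though only as a floor. Compound 2 has a limit and not a number, so the full size of this step remains unknown: the limit of > 20000 nM in this assay, at which 2 of the 3 values shown sit.

With a floor inside the usual scatter, the data do not establish whether moving the furan attachment changes the read-out in this assay by a real amount, and the step could be anywhere from negligible to large. Also open, going by these compounds, is how a phenyl ring, an aminomethyl group or a longer alkyl chain on the same aromatic carbon would read against furan-3-yl on the core of compound 3, since only the two furan attachments can be compared here.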